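Methoxy for bromo on the shared core

The source may report more compounds than this note shows. Statements on the series, on what has been measured and on what is new or still open speak of the compounds shown alone.

In a functional assay on NCI-H520 cells (Homo sapiens) for cytotoxicity (on this read-out lower numbers stand for stronger inhibition of growth and higher numbers for weaker inhibition of growth), compound 1 `COc1ccc(C2=C(c3ccc(SC)cc3)CC3CCCN3C2=O)cc1O` gives 6000 nM, compound 2 `COc1ccc(C2=C(c3ccc(SC)cc3)CC3CCCN3C2=O)cc1Br` gives 700 nM and compound 3 `CSc1ccc(C2=C(c3ccc(F)c(C)c3)C(=O)N3CCCC3C2)cc1` gives 500 nM. Compound 2 sits in the lower pair of these three numbers, and that pair is not separated: a 1.4-fold lower number from compound 2 to compound 3 (0.15 log units; within the scatter). The gap to the remaining compound is clear: an 8.6-fold lower number from compound 1 to compound 2 (0.93 log units; beyond the scatter).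

The next case is compound 4 `COc1ccc(C2=C(c3ccc(SC)cc3)CC3CCCN3C2=O)cc1OC`, with methoxy in place of bromo on an aromatic carbon, ortho to a methoxy group: methoxy in place of bromo on an aromatic carbon. For the measured compounds named here, no measured compound carries this group on that carbon. Going by the values given here, the hydroxy-to-bromo step above is the only one that changes the same carbon, and it is modest. The exchange of the whole aryl group, a 12-fold lower number from compound 1 to compound 3 (1.08 log units; beyond the scatter), is large but less direct. A move back towards compound 1 at 6000 nM is therefore expected, though only part of the way, so the expected change is a modest rise: a 2.6-fold higher number from compound 2 to compound 4 (0.41 log units; beyond the scatter). For compound 4 the estimated value is 1800 nM, with an expected range of 600 nM to 5000 nM.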

Compound 4, concentration for 50% growth inhibition: 2000 nM
Compound 4: middle estimate off by 1.1-fold (0.05 log units), on the low side, and the stated range covers the measured number.
By their numbers in this assay, from the lowest: compounds 3 and 2 (each within the scatter of the next); then compound 4; then compound 1.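

Methoxy on this carbon stands apart from both earlier groups in this assay: replacing bromo gives a 2.9-fold higher number from compound 2 to compound 4 (0.46 log units; beyond the scatter), while methylating the hydroxy oxygen gives a 3.0-fold lower number from compound 1 to compound 4 (0.48 log units; beyond the scatter). For the compounds shown here, the same carbon therefore now gives three separated numbers on the shared core, rising from bromo through methoxy to hydroxy, where the earlier compounds offered only the single comparison of hydroxy with bromo. Nothing available explains this order of the three groups.

Going by these compounds, whether an amine, a chloro group or a longer chain such as ethoxy on this carbon would fall nearer bromo or nearer hydroxy remains open. Also open, on these data alone, is whether the same order would hold with the methylthio group on the other aryl ring replaced by a carboxylic acid.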